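From compound 1 to compound 4: one five-membered ring for another

The source may report more compounds than this note shows. Statements on the series, on what has been measured and on what is new or still open speak of the compounds shown alone.

Measured so far:
compound 1, `O=C(O)c1cc(-n2ccnc2)ccc1O`, gives 75 mg/kg
compound 2, `O=C(O)c1cc(-c2ncccn2)ccc1O`, gives 100 mg/kg
compound 3, `O=C(O)c1ccc(-c2ncco2)cc1O`, gives only a limit, > 250 mg/kg

All three compounds were tested in a functional assay on the whole organism for inhibition, with Rattus norvegicus as the target, read by paw edema; on this read-out higher numbers stand for an effect only at larger amounts of compound and lower numbers for an effect already at smaller amounts. Compound 1 shows the lowest of the two numbers, with compound 2 giving 100 mg/kg, a gap that lies within the scatter, so the two cannot be ranked against each other. Compound 3 sits at the limit of > 250 mg/kg in this assay, at which 1 of the 3 values shown sits, and this is a limit of the assay rather than a number. Among the measured compounds shown here, no pair of measured compounds differs in only one place, so no measured step can guide the next one.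

Compound 4, `O=C(O)c1cc(C2N=NN=N2)ccc1O`, differs from compound 1 in a single place: a group of 5 heavy atoms (1 carbon, 4 nitrogen; one five-membered non-aromatic ring with 4 hetero atoms) in place of a group of 5 heavy atoms (3 carbon, 2 nitrogen; one five-membered aromatic ring with 2 hetero atoms), on an aromatic carbon. For the measured compounds named here, with no comparable step measured, the expected step from compound 1 to compound 4 is estimated as a small one, if any, toward a higher number, a 1.3-fold higher number from compound 1 to compound 4 (0.12 log units; within the scatter). On that basis compound 4 is expected to give about 100 mg/kg, in a range from 40 mg/kg to 250 mg/kg.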

Compound 4, dose for half-maximal effect: 110 mg/kg
For compound 4 the middle estimate is 1.1-fold (0.04 log units) below the measured one; the measured number falls inside the stated range.
By their numbers in this assay, from the lowest: compounds 1, 2 and 4 (each within the scatter of the next). At a limit, above all of these: compound 3.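

Among the compounds shown here, replacing the 1H-imidazol-1-yl group with a five-membered non-aromatic ring with 4 hetero atoms gives a 1.5-fold higher number from compound 1 to compound 4 (0.17 log units; within the scatter) as the first measured step at this position in this assay. The step shows that this place on the aromatic ring can carry either ring with no change in the number beyond the scatter, even though the two rings differ in aromaticity and in their mix of carbon and nitrogen. Nothing given here explains why the two rings give numbers this close.

As far as these compounds go, whether an open-chain group at the same place, such as an amine or a longer alkyl chain, would keep the number within the scatter remains open. Equally open, from the compounds shown here alone, is how the number would respond if a methoxy group took the place of the hydroxy group on the core.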